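Methyl for chloro on the anilino ring of compound 3

This account rests on a few compounds, and the source may have more. Where it says the series, first, only, none or still open, it means among the compounds named here.

Compound 1 `COc1ccc(Cl)cc1-c1nc(N)nc(Nc2ccc(Cl)cc2)n1` gives 70 nM; 45 nM (2 entries) in an assay on Sf9 cells for inhibition of 1-acyl-sn-glycerol-3-phosphate acyltransferase beta (Homo sapiens) (a higher number here means a weaker inhibitor, a lower number a stronger inhibitor), and compound 2 `CCOc1ccc(Cl)cc1-c1nc(N)nc(Nc2ccc(Cl)cc2)n1` gives 140 nM; 260 nM (2 entries) in the same assay; both sets of entries, the several entries of compound 1 in this assay, 70 nM; 45 nM (2 entries) and (the several entries of compound 2 in this assay, 140 nM; 260 nM (2 entries)), fall within the usual scatter of repeated measurements. Within the data shown here, compound 3 `COc1ccc(Cl)cc1-c1cc(N)cc(Nc2ccc(Cl)cc2)n1`, built on a different core, stands far apart from both: in this assay compound 3 gives 6500 nM, the only number reported for it, while two further entries for compound 3 gave no single number.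

Compound 4 `COc1ccc(Cl)cc1-c1cc(N)cc(Nc2ccc(C)cc2)n1` keeps the core of compound 3 and differs from it in one place: methyl in place of chloro on an aromatic carbon. Among the measured compounds shown here, no step between measured compounds covers this exchange, so the expected change rests on the structural change alone. The step from compound 3 to compound 4 is expected to be small, a 1.2-fold higher number from compound 3 to compound 4 (0.09 log units; within the scatter), with no clear direction beyond the scatter. Compound 4 is therefore estimated at 8000 nM, within a range from 3000 nM to 25000 nM, with a fair chance that this assay again reports only a limit for it.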

Compound 4, half-maximal inhibitory concentration: 29000 nM
The estimate for compound 4 lay 3.6-fold (0.56 log units) below the measured number; the whole stated range lies below it.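

In this assay, among these compounds, the change from 4-chlorophenyl to 4-methylphenyl is the first exchange in this set that touches only one place, and it gives a 4.5-fold higher number from compound 3 to compound 4 (0.65 log units; beyond the scatter) in the direction of a weaker inhibitor. Compounds 1 and 2 both carry the 4-chlorophenyl group, so they said nothing about this position, whereas this pair shows that a swap of one heavy atom for one heavy atom here, with no hydrogen-bond donor, acceptor or charge entering or leaving, can move the number beyond the scatter. Nothing measured here bears on why the step has this size.

On these data alone, whether a fluoro, bromo, trifluoromethyl or nitrile group at this place would track with chloro or with methyl remains open. So does whether the same exchange on the core of compound 1 would give a step of similar size.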